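Fluoro on the phenyl ring: from compound 3 to compound 4

The source may hold more compounds than are shown below. What is called first, only, known or untested is meant among the compounds shown, and "the series" means these compounds.

Measured compounds:
Compound 1, `CN1CCN(CC(=O)Nc2nc3ccccc3[nH]2)CC1`, gives 19.9%.
Compound 2, `CCN1CCN(CC(=O)Nc2nc3ccccc3[nH]2)CC1`, gives 26.6%.
Compound 3, `O=C(CN1CCN(c2ccccc2)CC1)Nc1nc2ccccc2[nH]1`, gives 11.5%.

All three numbers come from a functional assay, read by spectrophotometry, with a stated time of 30 min, tested at 25 ug/mL; a higher number here means a stronger effect of the compound at the concentration tested, a lower number a weaker effect. Compound 3 holds the lowest of the three numbers. Its nearest neighbour is compound 1: a number 8.4 percentage points lower from compound 1 to compound 3 (within the scatter). Its furthest is compound 2: a number 15.1 percentage points lower from compound 2 to compound 3 (beyond the scatter). The step between the two smaller groups, a number 6.7 percentage points higher from compound 1 to compound 2 (within the scatter), also stays within the scatter, so only the ethyl-to-phenyl exchange moves the number beyond it.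

Compound 4, `O=C(CN1CCN(c2ccccc2F)CC1)Nc1nc2ccccc2[nH]1`, is the next step from compound 3. The change is fluoro in place of hydrogen on an aromatic carbon, ortho to a large group; read one bond further out, it is phenyl to 2-fluorophenyl. Among the measured compounds shown here, none of the measured steps touches a substituent on that ring: the two steps ending at compound 3 exchange methyl or ethyl for phenyl and say nothing about what a fluoro on the phenyl does. For the measured compounds named here, with a single small atom entering and no comparable step in hand, the expectation is that a number 2.5 percentage points higher from compound 3 to compound 4 (within the scatter) stays within the scatter. Compound 4 is therefore estimated at 14%, in a range from 4% to 30%.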

Compound 4, a percentage reported as activity, at one concentration (the size of the read-out at that concentration, not a potency): 18.8%
The estimate for compound 4 lay 4.8 percentage points below the measured number, within the range that was stated.
By their numbers in this assay, from the lowest: compounds 3, 4, 1 and 2 (each within the scatter of the next, the first and the last beyond it).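

In this assay, the step of a number 7.3 percentage points higher from compound 3 to compound 4 (within the scatter) shows that 2-fluorophenyl in place of phenyl, with the fluoro ortho to a large group, leaves the read-out within the usual scatter of compound 3. The new compound also changes the comparison with the small alkyl groups on the amine nitrogen in a ring: where phenyl gave a number 15.1 percentage points lower from compound 2 to compound 3 (beyond the scatter) against ethyl, 2-fluorophenyl gives a number 7.8 percentage points lower from compound 2 to compound 4 (within the scatter) against ethyl and a number 1.1 percentage points lower from compound 1 to compound 4 (within the scatter) against methyl, so compound 4 cannot be told apart from either compound by this read-out. No measurement is at hand that would account for these steps.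

From the compounds shown here alone, whether fluoro on another carbon of the phenyl ring would read the same stays open, as does the outcome with chloro, methoxy or a nitrile in its place. Also open, going by these compounds, is what a longer chain or a benzyl group on the same amine nitrogen would do, set against the ethyl of compound 2 at 26.6% in this read-out.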